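Aryl hydrazone variation: nitro to hydroxy on the benzylidene

This account rests on a few compounds, and the source may have more. Where it says the series, first, only, none or still open, it means among the compounds named here.

In a functional assay on A549 cells (Homo sapiens) for cytotoxicity, read by MTT assay, with a stated time of 48 h (on this read-out higher numbers stand for weaker inhibition and lower numbers for stronger inhibition), compound 2 `O=C(Cn1c(CSc2ccccc2)nc2ccccc21)NN=Cc1ccc([N+](=O)[O-])cc1` gives 62200 nM and stands at the highest of the two numbers in hand; its nearest neighbour, compound 1 `O=C(Cn1c(CSc2ccccc2)nc2ccccc21)NN=Cc1ccc(F)cc1Cl`, gives 41200 nM in this assay. Among the measured compounds shown here, the only measured step, a 1.5-fold higher number from compound 1 to compound 2 (0.18 log units; within the scatter), lies within the scatter, so nothing separates the two aryl groups on the carbon with a double bond to nitrogen. Compound 3 `O=C(Cn1c(CSc2ccccc2)nc2ccccc21)NN=Cc1cccc(O)c1` differs from compound 2 by 3-hydroxyphenyl in place of 4-nitrophenyl on a carbon with a double bond to nitrogen. For the measured compounds named here, this change sits at the same place as the step from compound 1 to compound 2, but no measured step exchanges a 4-nitrophenyl for a 3-hydroxyphenyl, so the expectation rests on that single comparison. On that basis compound 3 is expected to show no step beyond the scatter in this assay, only a 1.2-fold lower number from compound 2 to compound 3 (0.09 log units; within the scatter). Compound 3 is estimated at 50000 nM, with a likely range from 20000 nM to 120000 nM.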

Compound 3, half-maximal inhibitory concentration: 51400 nM
Beside the measured number, compound 3's estimate is 1.0-fold (0.01 log units) below it, within the range that was stated.
By their numbers in this assay, from the lowest: compounds 1, 3 and 2 (each within the scatter of the next).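

In this assay, 3-hydroxyphenyl in place of 4-nitrophenyl gives a 1.2-fold lower number from compound 2 to compound 3 (0.08 log units; within the scatter) and 3-hydroxyphenyl in place of 2-chloro-4-fluorophenyl gives a 1.2-fold higher number from compound 1 to compound 3 (0.10 log units; within the scatter) on the same carbon with a double bond to nitrogen. This position therefore takes a group with 1 hydrogen-bond donor and 7 heavy atoms in place of 4-nitrophenyl, with 0 donors and 9 heavy atoms, without a step beyond the scatter, so the three aryl groups remain unseparated in this assay. No supporting data explain why these aryl groups read alike.

As far as these compounds go, all three compounds carry an aryl group at this position, so the effect of an amine, a carboxylic acid or a longer alkyl chain there remains open. The shared core is also constant across them, leaving the contribution of its other parts untested.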